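The source may report more compounds than this note shows. Statements on the series, on what has been measured and on what is new or still open speak of the compounds shown alone.

Measured compounds:
compound 1 `CC(C)[C@H](C(=O)Nc1nncs1)c1ccc(Cl)cc1`: 115%
compound 2 `CC(C)[C@H](C(=O)Nc1nnc(C(F)(F)F)s1)c1ccc(Cl)cc1`: 115%

Both values come from a functional assay on CHO cells for agonist activity at Free fatty acid receptor 2 (Homo sapiens), read by cAMP accumulation; on this read-out higher numbers stand for larger maximal responses and lower numbers for smaller maximal responses. Compound 1 stands level with compound 2 at the digits shown; the one measured step, no change at the digits printed from compound 1 to compound 2 (within the scatter), brought no change within the scatter. So the only comparison to hand says that altering a group on the aromatic ring attached to the amide nitrogen left the maximal response as it was.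

Compound 3 `CC(C)[C@H](C(=O)Nc1ncc(C#N)s1)c1ccc(Cl)cc1` is not yet measured. It differs from compound 1 as follows: 5-cyano-1,3-thiazol-2-yl in place of 1,3,4-thiadiazol-2-yl on an amide-type nitrogen. Going by the values given here, this exchanges the whole five-membered ring on the amide nitrogen rather than a single group on it, a kind of change for which no step has been measured here. The step from compound 1 to compound 2 bears on it only loosely, in that the same part of the molecule was varied and nothing moved beyond the scatter. On that basis the expected step of a number 5 percentage points lower from compound 1 to compound 3 (within the scatter) is no change beyond the scatter, with the range widened because the ring itself is replaced.

Compound 3 is therefore estimated at 110%, between 85% and 135%.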

Compound 3, largest response reached (reported as efficacy), in percent of the reference or control that the assay uses: 105%
The estimate for compound 3 lay 5 percentage points above the measured number; low and high end bracket the measured number.
By their numbers in this assay, from the lowest: compounds 3, 1 and 2 (each within the scatter of the next).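

In this assay, exchanging the 1,3,4-thiadiazol-2-yl ring on the amide-type nitrogen for 5-cyano-1,3-thiazol-2-yl gives a number 10 percentage points lower from compound 1 to compound 3 (within the scatter). Going by these compounds alone, the earlier pair showed only that one group on the ring could be swapped with the maximal response staying within the scatter, whereas this step shows the same for a replacement of the ring itself, with one ring hetero atom fewer and a nitrile added. So, for these three compounds, the largest response reached does not separate the groups placed on this nitrogen, even when the change is larger than a single group; nothing available here indicates what lies behind this outcome.

From the compounds shown here alone, it remains open whether the response would also hold with a plain phenyl ring or a saturated ring such as piperidine on the amide nitrogen, or with a carboxylic acid or an amine in place of the nitrile. Since this read-out reports only the largest response, it also leaves open how much of each compound is needed to reach it, and the rest of the molecule stays the same throughout.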